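A few compounds are considered here, and "the series" means these few. Any claim that something is new, unique, unknown or untested is made for them only; others in the source may bear on it.

Measured compounds:
compound 1 `Nc1ccccc1/N=C\c1cc(=O)oc2cc(OCc3ccccc3)ccc12`: 34600 nM in a functional assay, read by spectrophotometry, with a stated time of 1 h; a higher number here means a weaker inhibitor, a lower number a stronger inhibitor
compound 2 `O=c1cc(/C=N\O)c2c(OCc3ccccc3)cc(OCc3ccccc3)cc2o1`: "not active" (no number reported)
compound 3 `O=c1cc(/C=N\c2ccc(O)cc2)c2c(OCc3ccccc3)cc(OCc3ccccc3)cc2o1`: 107000 nM

Among the two compounds with a reported number in this assay, compound 3 stands at the higher one, with compound 1 giving a number beyond the usual scatter below it, while compound 2 gives no number at all. Compound 4 `Nc1ccccc1/N=C\c1cc(=O)oc2cc(OCc3ccccc3)cc(OCc3ccccc3)c12` differs from compound 3 in one place: 2-aminophenyl in place of 4-hydroxyphenyl on a double-bonded nitrogen. For the measured compounds named here, no measured pair shows this change directly. A moderate drop in this assay, beyond the scatter, is expected, because compound 1 carrying the same 2-aminophenyl gives 34600 nM, though compound 1 also differs in its core. This estimate means an expected step of a 2.1-fold lower number from compound 3 to compound 4 (0.33 log units; beyond the scatter). Compound 4 is therefore estimated at 50000 nM, with a range from 20000 nM to 150000 nM.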

Compound 4, half-maximal inhibitory concentration: 624000 nM
Beside the measured number, compound 4's estimate is 12-fold (1.10 log units) below it, outside the stated range (above it).
By their numbers in this assay, from the lowest: compound 1; then compound 3; then compound 4.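

Putting 2-aminophenyl in place of 4-hydroxyphenyl on the double-bonded nitrogen gives, in this assay, a 5.8-fold higher number from compound 3 to compound 4 (0.77 log units; beyond the scatter), so on this shared core the change weakens inhibition. Benzyloxy in place of hydrogen on an aromatic carbon gives an 18-fold higher number from compound 1 to compound 4 (1.26 log units; beyond the scatter), showing that 2-aminophenyl does not carry the lower number of compound 1 onto the core of compound 4. Nothing measured here explains either step. The compounds shown leave open whether 4-hydroxyphenyl on the core of compound 1 would also give a lower number, and how a carboxylic acid on that phenyl ring, or methoxy in place of benzyloxy, would read.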